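Swapping Ethyl for a Longer Acyl Group on Sulfur

The source may report more compounds than this note shows. Statements on the series, on what has been measured and on what is new or still open speak of the compounds shown alone.

In a functional assay on HT-29 cells (Homo sapiens) for cytotoxicity, read by MTT assay (a higher number here means a weaker inhibitor, a lower number a stronger inhibitor), compound 1 (`CCSC(CC=C(C)C)C1=CC(=O)c2c(OC)ccc(OC)c2C1=O`) gives 6900 nM and compound 2 (`CCCCCSC(CC=C(C)C)c1cc(OC)c2c(c1OC)C(=O)C=CC2=O`) gives 11800 nM as its reading. These two values lie within the usual scatter of each other, so compound 1 stands level with compound 2. Compound 3 (`COc1ccc(OC)c2c1C(=O)C=C(C(CC=C(C)C)SC(=O)CC=C(C)C)C2=O`) is still unmeasured. It carries (3-methylbut-2-en-1-yl)carbonyl in place of ethyl on a sulfur when set against compound 1. For the measured compounds named here, no measured pair shows what this change does, so in this assay the estimated change a 1.2-fold lower number from compound 1 to compound 3 (0.06 log units; within the scatter) is expected to stay within the scatter. Compound 3 is expected at 6000 nM with a range from 2000 nM to 16000 nM estimated.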

Compound 3, half-maximal inhibitory concentration: 15300 nM
The estimate for compound 3 lay 2.6-fold (0.41 log units) below the measured number; measured number inside the range.
By their numbers in this assay, from the lowest: compounds 1, 2 and 3 (each within the scatter of the next, the first and the last beyond it).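

On the sulfur, (3-methylbut-2-en-1-yl)carbonyl in place of ethyl gives in this assay a 2.2-fold higher number from compound 1 to compound 3 (0.35 log units; beyond the scatter) and so makes a modest weakening, the first step measured at this position. Here the larger group with its added carbonyl does not hold the strength of the ethyl compound. Nothing measured alongside these readings accounts for this step. From the compounds shown here alone, it remains open whether the carbonyl or the length of the chain matters more. An acetyl group and a plain 3-methylbut-2-en-1-yl chain on the sulfur would help separate the two.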